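This account rests on a few compounds, and the source may have more. Where it says the series, first, only, none or still open, it means among the compounds named here.

Measured so far in an assay on isolated protein for displacement of a labelled ligand from metabotropic glutamate receptor 5 (Homo sapiens), with a stated time of 60 min, tested at 1 uM; a higher number here means more inhibition at the concentration tested (going by the name of the read-out), a lower number less inhibition:
compound 1 `COc1ccc(S(=O)(=O)c2cnc3ccc(C)cc3c2N2CCC(C)CC2)cc1`, for which compound 1 gives 62%
compound 2 `Cc1ccc2ncc(S(=O)(=O)c3cc(Cl)cc(Cl)c3)c(N3CCC(C)CC3)c2c1`, for which compound 2 gives 75%
compound 3 `Cc1ccc2ncc(S(=O)(=O)c3ccc(F)c(Cl)c3)c(N3CCC(C)CC3)c2c1`, for which compound 3 gives 93%

Compound 3 stands highest of the three numbers in this assay: a number 18 percentage points higher from compound 2 to compound 3 (beyond the scatter), and a number 31 percentage points higher from compound 1 to compound 3 (beyond the scatter). Every change so far sits on the aryl group attached to the sulfonyl sulfur, the shared core being held constant.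

Compound 4 `Cc1ccc2ncc(S(=O)(=O)c3cc(F)cc(F)c3)c(N3CCC(C)CC3)c2c1` is the next to be measured in this assay. The change from compound 3: 3,5-difluorophenyl in place of 3-chloro-4-fluorophenyl on a sulfonyl sulfur

For the measured compounds named here, two measured steps bear on it. The nearest is the return toward a 3,5-dihalogen pattern, which in this assay was left in the opposite direction: a number 18 percentage points higher from compound 2 to compound 3 (beyond the scatter). The other is a number 13 percentage points higher from compound 1 to compound 2 (beyond the scatter), showing that a 3,5-dihalogen pattern still sits well above the methoxy compound. Going by the values given here, no measured compound carries 3,5-difluorophenyl, so the weight of fluorine against chlorine at this position is not established. The expected step in this assay is a modest fall, a number 13 percentage points lower from compound 3 to compound 4 (beyond the scatter), because of a number 18 percentage points higher from compound 2 to compound 3 (beyond the scatter). Compound 4 is therefore estimated at 80% in this assay, within a range of 62% to 93%.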

Compound 4, a percentage reported as inhibition, at one concentration (the size of the read-out at that concentration, not a potency): 72%
The estimate for compound 4 lay 8 percentage points above the measured number, and the stated range covers the measured number.
By their numbers in this assay, from the lowest: compounds 1, 4 and 2 (each within the scatter of the next, the first and the last beyond it); then compound 3.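

In this assay, a number 21 percentage points lower from compound 3 to compound 4 (beyond the scatter) and a number 3 percentage points lower from compound 2 to compound 4 (within the scatter), so exchanging chlorine for fluorine within the 3,5-dihalogen pattern gives no readable change, while 3-chloro-4-fluorophenyl on the sulfonyl sulfur remains apart from both 3,5-dihalogen compounds. The two 3,5-dihalogen groups do not stand alike against 4-methoxyphenyl: a number 10 percentage points higher from compound 1 to compound 4 (within the scatter), whereas a number 13 percentage points higher from compound 1 to compound 2 (beyond the scatter) and so compound 4 sits in an unresolved middle, not separated from either compound 1 or compound 2. No measured evidence on the series accounts for these differences at this position.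

The halogen identity and the substitution pattern both differ between compound 3 and compound 4, so the series does not yet separate which of the two carries the step, and a 3-chloro-5-fluorophenyl group would be the direct test. As far as these compounds go, it also remains open whether a non-halogen group on the aryl ring, such as a nitrile, an amine or a carboxylic acid, would hold the read-out at this concentration, and how these percentages would translate into potency.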